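Oxadiazole series on the shared core: step to compound 3

This account rests on a few compounds, and the source may have more. Where it says the series, first, only, none or still open, it means among the compounds named here.

Of the compounds shown here, two of the shared core have numbers so far. Compound 1 `Cc1ccc(C)c(N2CCN(Cc3nnc(-c4cc(S(N)(=O)=O)c(SCc5ccccc5)cc4Cl)o3)CC2)c1` in a functional assay on HCT-116 cells (Homo sapiens) for cytotoxicity, read by MTT assay, with a stated time of 72 h (on this read-out lower numbers stand for stronger inhibition and higher numbers for weaker inhibition), gives 17000 nM. Compound 2 `NC(=O)c1cn(Cc2nnc(-c3cc(S(N)(=O)=O)c(SCc4ccccc4)cc3Cl)o2)nn1` in this assay gives 72000 nM, the highest of the two numbers; its nearest neighbour is compound 1, whose number is lower by a margin beyond the scatter. Among the compounds with values here, no single-change step between measured compounds is available, so the two values show only that compound 2 sits at the weaker end.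

Compound 3 `NS(=O)(=O)c1cc(-c2nnc(/C=C/c3c(Cl)cccc3Cl)o2)c(Cl)cc1SCc1ccccc1` differs from compound 2 in one place: 2-(2,6-dichlorophenyl)ethenyl in place of (4-carbamoyl-1H-1,2,3-triazol-1-yl)methyl on an aromatic carbon. The group that leaves carries the donor and acceptors; the group that enters carries none. Since compound 1, which also lacks the carbamoyl-triazole, gives 17000 nM, compound 3 is expected to move toward a lower number, a modest step of a 2.9-fold lower number from compound 2 to compound 3 (0.46 log units; beyond the scatter), likely at the edge of the scatter. Compound 3 is estimated at 25000 nM, within 6000 nM to 90000 nM.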

Compound 3, half-maximal inhibitory concentration: 32000 nM
Compound 3: the middle estimate sits 1.3-fold (0.11 log units) below what was measured; the measured number falls inside the stated range.
By their numbers in this assay, from the lowest: compounds 1 and 3 (each within the scatter of the next); then compound 2.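

At the aromatic carbon of the five-membered ring with 2 nitrogen and 1 oxygen, this assay gives a 2.3-fold lower number from compound 2 to compound 3 (0.35 log units; beyond the scatter) when 2-(2,6-dichlorophenyl)ethenyl replaces (4-carbamoyl-1H-1,2,3-triazol-1-yl)methyl. Within the data shown here, this is the first single-change step: the number at this position responds to the group it carries, and a group with 0 hydrogen-bond donors and 0 hydrogen-bond acceptors brings no loss relative to compound 2. No supporting data bear on the cause of this step.

The ethenyl linker and the dichlorophenyl ring enter together, so their separate contributions remain unresolved. As far as these compounds go, how a carboxylic acid or a plain aminomethyl group on this same carbon would read against compound 3 also remains open.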